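A few compounds are considered here, and "the series" means these few. Any claim that something is new, unique, unknown or untested is made for them only; others in the source may bear on it.

Measured compounds:
compound 1, `O=C1O[C@@H](CO)CN1c1ccc(-n2cc(-c3ccccn3)cn2)c(F)c1` — in an ADME assay on L02 cells (Homo sapiens) for cytotoxicity, read by MTT assay, with a stated time of 48 h (on this read-out lower numbers stand for stronger inhibition and higher numbers for weaker inhibition), compound 1 gives 59 ug/mL.
compound 2, `O=C1O[C@@H](CN2CCC(O)CC2)CN1c1ccc(-n2cc(-c3ccccn3)cn2)c(F)c1` — in this assay compound 2 gives > 400 ug/mL, which is a limit of the assay and not a number.

Among the compounds with values here, compound 2 therefore stands at the weaker end of the two numbers so far, and it is known only as a limit, as recorded in the limit of > 400 ug/mL in this assay, at which 1 of the 2 values shown sits. Within the data shown here, the single measured step, an at least 6.7-fold higher number from compound 1 to compound 2 (0.83 log units; beyond the scatter), runs towards weaker inhibition and is at least modest in size.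

Compound 3, `O=C1CCC(=O)N1C[C@H]1CN(c2ccc(-n3cc(-c4ccccn4)cn3)c(F)c2)C(=O)O1`, has not yet been measured. It differs from compound 2 in one place: 2,5-dioxopyrrolidin-1-yl in place of 4-hydroxypiperidin-1-yl on a saturated chain carbon bound to a saturated ring carbon. Among the measured compounds shown here, no measured step covers this particular exchange; the only step available, an at least 6.7-fold higher number from compound 1 to compound 2 (0.83 log units; beyond the scatter), concerns a different replacement at that carbon and reaches only a limit, so the distance compound 2 has moved is itself unknown. The two groups share a count of heavy atoms and of acceptors but the entering group brings no donor and two double bonds outside aromatic rings.

Compound 3 is expected to give about 200 ug/mL in this assay. The expected range for compound 3 runs from 60 ug/mL to 400 ug/mL. The expected step is an at least 2.0-fold lower number from compound 2 to compound 3 (0.30 log units; that floor lies within the scatter), with a real chance that only a limit is returned.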

Compound 3, half-maximal inhibitory concentration: > 400 ug/mL
Compound 3 gave a limit, no number; the forecaster's own chance of this, stated with the estimate: 40%; at least 2.0-fold (0.30 log units) between middle value and limit.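

Replacing hydroxy with 2,5-dioxopyrrolidin-1-yl on a saturated chain carbon bound to a saturated ring carbon gives an at least 6.7-fold higher number from compound 1 to compound 3 (0.83 log units; beyond the scatter) in this assay, so the move towards weaker inhibition seen with 4-hydroxypiperidin-1-yl is not confined to that one group. The hydrogen-bond donor of 4-hydroxypiperidin-1-yl is absent from 2,5-dioxopyrrolidin-1-yl, and the entering group is a five-membered rather than a six-membered ring, yet for these two compounds the read-out still ends in a limit of the assay and not a number. The step between compound 2 and compound 3 cannot be read, because both values are limits and neither can be placed relative to the other: the limit of > 400 ug/mL in this assay, at which 2 of the 3 values shown sit.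

Going by these compounds, whether an amine, a carboxylic acid or a longer chain at this carbon would return a number rather than a limit stays open. Also open is whether the higher number depends on a ring at this carbon at all, since both replacements shown for hydroxy carry one.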